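The source may hold more compounds than are shown below. What is called first, only, known or untested is meant among the compounds shown, and "the series" means these compounds.

Values from a functional assay on MCF7 cells (Homo sapiens) for antiproliferative activity, read by MTT assay, with a stated time of 48 h (a higher number here means a weaker inhibitor, a lower number a stronger inhibitor), for the compounds measured so far
Compound 1 `Cc1cc2nc(-c3cn(-c4ccccc4)nc3-c3ccccc3)[nH]c2cc1C` gives > 50000 nM as a limit
Compound 2 `Cc1ccc2[nH]c(-c3cn(-c4ccccc4)nc3-c3ccc(F)cc3)nc2c1` gives 1120 nM as a number

Among the compounds with values here, compound 2 holds the only actual number so far, at 1120 nM in this assay, which makes it the one firm reference point. For compound 1, the reading of > 50000 nM is a limit of the assay and not a number.

Compound 3 `Cc1cc2nc(-c3cn(-c4ccccc4)nc3-c3ccc(F)cc3)[nH]c2cc1C` differs from compound 2 by a single edit, methyl in place of hydrogen on an aromatic carbon. Within the data shown here, no measured pair in this small series isolates that change, so its size in this assay cannot be read directly from the data. Among the measured compounds shown here, the one other reading, from compound 1 at > 50000 nM, is a limit, and it tilts the expectation towards weaker activity. The estimated change a 2.7-fold higher number from compound 2 to compound 3 (0.43 log units; beyond the scatter) is expected to be modest but beyond the usual scatter, towards a higher number, with wide uncertainty. For compound 3, the expected value is 3000 nM, with an estimated range of 600 nM to 20000 nM.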

Compound 3, half-maximal inhibitory concentration: 27200 nM
For compound 3 the middle estimate is 9.1-fold (0.96 log units) below the measured one; measured number above the stated range.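

In this assay, one added methyl on an aromatic carbon of the six-membered ring of carbon only, ortho to a methyl group, proves to matter far more than a single heavy atom might suggest, giving a 24-fold higher number from compound 2 to compound 3 (1.39 log units; beyond the scatter). Within the data shown here, this is the first measured pair to isolate that change, and it shows that a small edit at this position can cost much of the activity of compound 2. The single edit that brings in a fluoro group gives an at least 1.8-fold lower number from compound 1 to compound 3 (0.26 log units; that floor lies within the scatter), but the true size of this step stays unknown because compound 1 sits at a limit and not at a number: the limit of > 50000 nM in this assay, at which 1 of the 3 values shown sits.

The compounds shown leave open whether the loss is specific to methyl, or whether a chlorine atom, a methoxy group or an amine at the same position would give a similar result. They also give no measured property that could explain why this one methyl has so large an effect.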